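The compounds below may be only part of what the source reports. "The series", "measured", "known", "first", "only" and "open" are said of these compounds alone.

Compound 1 `O=C(O)CC(NS(=O)(=O)c1ccccc1)c1ccccc1` is the starting point in a functional assay on MDA-MB-231 cells (Homo sapiens) for antiproliferative activity, read by MTT assay, with a stated time of 24 h; on this read-out lower numbers stand for stronger inhibition and higher numbers for weaker inhibition. Compound 1 gives > 100000 nM, which is a limit of the assay and not a number. Compound 3 `O=C(O)CC(NS(=O)(=O)c1ccccc1)c1ccccc1F` gives > 100000 nM, which is again only a limit. Compound 3 therefore stands with compound 1 at the limit of > 100000 nM in this assay, at which 2 of the 3 values shown sit. For the measured compounds named here, the one true number so far comes from compound 2 `O=C(O)CC(NC(=O)c1ccc(Cl)cc1Cl)c1ccccc1F`, which gives 89300 nM.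

Compound 4 `O=C(O)CC(NS(=O)(=O)c1ccc(C(F)(F)F)cc1)c1ccccc1F` differs from compound 3 by trifluoromethyl in place of hydrogen on an aromatic carbon, with trifluoromethyl in place of hydrogen on an aromatic carbon. Going by the values given here, the only measured step is a step that the two limits leave unreadable from compound 1 to compound 3, and it concerns fluoro rather than trifluoromethyl, so it offers no size to carry over. No clear shift beyond the scatter is therefore expected in this assay, and weak activity remains likely, in line with compound 2 at 89300 nM. The expected step, a number no higher from compound 3 to compound 4 (the limit leaves the size open), is small, and the result may again be only a limit. For compound 4 the estimated value is 100000 nM, with an expected range of 50000 nM to 200000 nM.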

Compound 4, half-maximal inhibitory concentration: 47100 nM
The estimate for compound 4 lay 2.1-fold (0.33 log units) above the measured number; measured number below the stated range.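

With trifluoromethyl entering on an aromatic carbon, para to a large group, the read-out shows an at least 2.1-fold lower number from compound 3 to compound 4 (0.32 log units; beyond the scatter) in this assay, and this is the only step shown whose size can be read at all. It shows that a change at this carbon can move the read-out, as compound 4 gives a true number of 47100 nM where the two earlier sulfonamides gave none. The size of the step is only a lower bound, because compound 3 sits at a limit of the assay and not at a number: the limit of > 100000 nM in this assay, at which 2 of the 4 values shown sit.

The compounds shown leave open whether a methyl group, a methoxy group or an amine at this same carbon would move the number as well. They also leave open whether trifluoromethyl would do the same on the core of compound 1, which lacks the fluoro group.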